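Swapping a Dichlorophenyl for a Chlorophenyl

This account rests on a few compounds, and the source may have more. Where it says the series, first, only, none or still open, it means among the compounds named here.

Compound 2 `O=c1ccc(-c2ccc3cn[nH]c3c2)cn1Cc1ccc(Cl)c(Cl)c1` gives the lowest of the two numbers recorded so far in an assay for inhibition of MAP kinase-interacting serine/threonine-protein kinase 1 (Homo sapiens), read by luminescence and ADP-Glo, with a stated time of 2 h (a lower number here means a stronger inhibitor, a higher number a weaker inhibitor), at 62 nM. Compound 1 `NC(=O)c1ccccc1Cn1cc(-c2ccc3cn[nH]c3c2)ccc1=O`, which carries a different group at the same place, stands at 878 nM, a gap beyond the usual scatter. Compound 3 `O=c1ccc(-c2ccc3cn[nH]c3c2)cn1Cc1ccccc1Cl` is not yet measured; it differs from compound 2 by 2-chlorophenyl in place of 3,4-dichlorophenyl on a saturated chain carbon bound to an aromatic nitrogen. For the measured compounds named here, no measured step of this kind exists, so the expectation rests on the two values: a moderate loss beyond the scatter is expected, as compound 1 gives 878 nM. The expected step is a 3.5-fold higher number from compound 2 to compound 3 (0.55 log units; beyond the scatter). Compound 3 is estimated at 220 nM, within 60 nM to 800 nM.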

Compound 3, half-maximal inhibitory concentration: 80 nM
Compound 3: the middle estimate sits 2.8-fold (0.44 log units) above what was measured; low and high end bracket the measured number.
By their numbers in this assay, from the lowest: compounds 2 and 3 (each within the scatter of the next); then compound 1.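

In this assay, 2-chlorophenyl in place of 3,4-dichlorophenyl on a saturated chain carbon bound to an aromatic nitrogen gives a 1.3-fold higher number from compound 2 to compound 3 (0.11 log units; within the scatter) and stays within the scatter, so the second chlorine and the different chlorine placement make no readable difference here. Chloro in place of carbamoyl on an aromatic carbon gives an 11-fold lower number from compound 1 to compound 3 (1.04 log units; beyond the scatter) as a large step, which ties the weaker value of compound 1 to the carbamoyl group. Nothing shown explains either step. The compounds shown leave open how an unsubstituted phenyl, a fluoro or a methoxy group would fare at this position, and whether a longer chain would be accepted.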